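Chloro substitution on the hydroxymethylphenyl ring of compound 1

The source may report more compounds than this note shows. Statements on the series, on what has been measured and on what is new or still open speak of the compounds shown alone.

Measured compounds:
compound 1 `Nc1nc(NCc2ccccc2)nc(-c2ccccc2CO)n1`: 4.35
compound 2 `CNc1nc(NCc2ccccc2)nc(-c2ccccc2CO)n1`: 4.51
compound 3 `Nc1nc(NCc2ccccc2)nc(-c2ccc(F)cc2CO)n1`: 4.58

All three numbers come from a functional assay on cells for positive allosteric modulation of G-protein coupled receptor 68 (Homo sapiens), read by a luciferase reporter and cAMP accumulation, with a stated time of 30 min, at pH 6.8 and pH 8.3, in the presence of a further agent that is not named here; on this read-out lower numbers stand for lower potency and higher numbers for higher potency (the scale is a negative logarithm). Compound 1 gives the smallest number of the three, but neither of the other two is separated from it by more than the scatter: the nearest is compound 2, with a number 0.16 log units higher from compound 1 to compound 2 (within the scatter), and the furthest is compound 3, with a number 0.23 log units higher from compound 1 to compound 3 (within the scatter). No ranking among the three is therefore supported.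

Compound 4 `Nc1nc(NCc2ccccc2)nc(-c2c(Cl)cccc2CO)n1` has not been measured. It differs from compound 1 by chloro in place of hydrogen on an aromatic carbon. Among the compounds with values here, the only measured step that bears directly on this change is the one from compound 1 to compound 3, a halogen entering the same ring, which gave a number 0.23 log units higher from compound 1 to compound 3 (within the scatter). The step to compound 2 alters a different part of the molecule and was likewise small. Both changes to compound 1 so far moved the number only a little and upward, so for compound 4 a step of similar size, a number 0.15 log units higher from compound 1 to compound 4 (within the scatter), is expected, without confidence in its direction beyond the scatter. Compound 4 is estimated at 4.5, with a range of 4 to 5 in this assay.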

Compound 4, negative logarithm of the antagonist equilibrium constant: 4.43
The estimate for compound 4 lay 0.07 log units above the measured number, within the range that was stated.
By their numbers in this assay, from the lowest: compounds 1, 4, 2 and 3 (each within the scatter of the next).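

In this assay, chloro in place of hydrogen on an aromatic carbon, ortho to a large group and meta to a hydroxymethyl group, gives a number 0.08 log units higher from compound 1 to compound 4 (within the scatter). The earlier compounds shown here showed only fluoro on this ring, with a number 0.23 log units higher from compound 1 to compound 3 (within the scatter); chloro at this place adds a second halogen change that stays within the scatter, so neither halogen step marks out a place on the ring where the number responds to substitution. No measurement bears on why this step is so small.

Open is whether an amine, a carboxylic acid or a methoxy group on this same aromatic carbon would give a step beyond the scatter, as the compounds shown carry only hydrogen or chloro there. Also open, going by these compounds, is whether chloro at this place and methyl on the ring nitrogen substituent, with a number 0.16 log units higher from compound 1 to compound 2 (within the scatter) for the latter alone, would together move the number beyond the scatter of compound 1.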